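Benzoyl in Place of Hydrogen on the Hydroxymethyl Oxygen

This account rests on a few compounds, and the source may have more. Where it says the series, first, only, none or still open, it means among the compounds named here.

Measured compounds:
compound 1, `COC1=CC(=O)c2c(c(CO)c(C3CC3)n2C)C1=O`: 820000 nM
compound 2, `COC1=CC(=O)c2c(c(COC(=O)c3ccccc3F)cn2C)C1=O`: 40 nM

In a functional assay on V79-379A cells (Cricetulus griseus) for cytotoxicity, read by MTT assay, in the presence of a further agent that is not named here (on this read-out lower numbers stand for stronger inhibition and higher numbers for weaker inhibition), compound 1 gives 820000 nM, the highest of the two numbers shown. Within the data shown here, compound 2 gives 40 nM in this assay, a far lower number; compound 2 differs from compound 1 in more than one place, so no single step is drawn between them, and only the two values themselves can be compared. Compound 3 `COC1=CC(=O)c2c(c(COC(=O)c3ccccc3)c(C3CC3)n2C)C1=O` differs from compound 1 in one place: benzoyl in place of hydrogen on an oxygen on a saturated carbon, which, cut one bond further out, reads hydroxy to benzoyloxy. Among the measured compounds shown here, no measured pair records this step. For the measured compounds named here, compound 2, which carries a related benzoyloxy-type group, stands at a very low number in this assay, and that is the only guide available. The step from compound 1 to compound 3 is therefore expected to be large and downward, a 2700-fold lower number from compound 1 to compound 3 (3.44 log units; beyond the scatter), though with a wide range since compound 2 also differs elsewhere. Compound 3 is estimated to give 300 nM in this assay, between 20 nM and 10000 nM.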

Compound 3, half-maximal inhibitory concentration: 1000 nM
Compound 3: middle estimate off by 3.3-fold (0.52 log units), on the low side; low and high end bracket the measured number.
By their numbers in this assay, from the lowest: compound 2; then compound 3; then compound 1.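

In this assay, benzoyl in place of hydrogen on the oxygen on a saturated carbon gives an 820-fold lower number from compound 1 to compound 3 (2.91 log units; beyond the scatter), with the rest of the molecule unchanged. Until now the values could not tie any change in this read-out to one place, and this pair ties a large one to this oxygen alone: the free hydroxy is not needed for a low number here, and the benzoyl group is accepted at this position. Nothing measured here bears on the reason for a step of this size.

From the compounds shown here alone, whether the benzoyl ring itself matters, or any group on this oxygen would serve, stays open; an acetyl group or a plain methyl ether in the same place would separate the two. Among these compounds, compound 2 and compound 3 differ in more than one place, so no step between them can be read, and what the fluorine on the benzoyl ring and the cyclopropyl group each contribute remains unsettled.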